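Ester to Dimethylamide on a Naphthylpyridine Acrylate

A few compounds are considered here, and "the series" means these few. Any claim that something is new, unique, unknown or untested is made for them only; others in the source may bear on it.

Compound 1 `NNC(=O)CCc1ccncc1-c1ccc2ccccc2c1` gives > 10000 nM in a functional assay on A549 cells (Homo sapiens) for inhibition, read by sulforhodamine B assay, with a stated time of 72 h (on this read-out lower numbers stand for stronger inhibition of growth and higher numbers for weaker inhibition of growth), which is a limit of the assay.
Compound 2 `O=C(O)/C=C/c1ccncc1-c1ccc2ccccc2c1` gives > 10000 nM in this assay, also a limit.
Compound 3 `COC(=O)/C=C/c1ccncc1-c1ccc2ccccc2c1` gives 760 nM in this assay.

Going by the values given here, compound 3 is the only compound with a number; the other two sit at the limit of > 10000 nM in this assay, at which 2 of the 3 values shown sit. The steps of an at least 13-fold lower number from compound 2 to compound 3 (1.11 log units; beyond the scatter) and an at least 13-fold lower number from compound 1 to compound 3 (1.11 log units; beyond the scatter) show that the group on the carbonyl decides whether growth inhibition is seen at all. Compound 4 `CN(C)C(=O)/C=C/c1ccncc1-c1ccc2ccccc2c1` carries dimethylamino in place of methoxy on a carbonyl carbon. Among the compounds with values here, no measured step covers an ester turning into an amide, so the direction is open; the dimethylamide keeps a neutral carbonyl, unlike the acid of compound 2. Compound 4 is expected to show a modest weakening, a 2.6-fold higher number from compound 3 to compound 4 (0.42 log units; beyond the scatter), giving an estimate of 2000 nM with a range from 500 nM to 10000 nM.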

Compound 4, concentration for 50% growth inhibition: 5800 nM
Compound 4: middle estimate off by 2.9-fold (0.46 log units), on the low side, within the range that was stated.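

In this assay, dimethylamino in place of methoxy on this carbonyl carbon still leaves a measurable number, but growth inhibition weakens: a 7.6-fold higher number from compound 3 to compound 4 (0.88 log units; beyond the scatter). So the methoxy ester is not the only group here that gives a number, though it gives the lower one. Only floors can be read for an at least 1.7-fold lower number from compound 2 to compound 4 (0.23 log units; that floor lies within the scatter) and for an at least 1.7-fold lower number from compound 1 to compound 4 (0.23 log units; that floor lies within the scatter), because those two compounds sit at a limit of the assay: the limit of > 10000 nM in this assay, at which 2 of the 4 values shown sit.

Open, as far as these compounds go, is whether an ethyl ester or a methylamide would lie nearer compound 3 or compound 4.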